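The source may report more compounds than this note shows. Statements on the series, on what has been measured and on what is new or still open speak of the compounds shown alone.

Measured so far in an in vitro functional assay on cells (Fibroblast) for agonist activity at Alpha-1A adrenergic receptor (Homo sapiens); a lower number here means that less compound is needed, a higher number that more compound is needed for the effect: compound 1 `Cn1ccc(-c2ccccc2NCC2=NCCN2)n1` gives 3.16 nM; compound 2 `Cn1cccc1-c1ccccc1NCC1=NCCN1` gives 20 nM.

Compound 2 has the highest of the two numbers; its nearest is that of compound 1, and the step of a 6.3-fold higher number from compound 1 to compound 2 (0.80 log units; beyond the scatter) separates them. Compound 3 `Cn1ccnc1-c1ccccc1NCC1=NCCN1` carries 1-methyl-1H-imidazol-2-yl in place of 1-methyl-1H-pyrrol-2-yl on an aromatic carbon. Within the data shown here, the only measured step that bears on this, a 6.3-fold higher number from compound 1 to compound 2 (0.80 log units; beyond the scatter), replaced 1-methyl-1H-pyrazol-3-yl by 1-methyl-1H-pyrrol-2-yl and raised the number; compound 3 brings in a ring with two hetero atoms again, so a lower number of modest size is expected, a 3.3-fold lower number from compound 2 to compound 3 (0.52 log units; beyond the scatter). Compound 3 is therefore estimated at 6 nM, within 2 nM to 20 nM.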

Compound 3, half-maximal effective concentration: 6.31 nM
The estimate for compound 3 lay 1.1-fold (0.02 log units) below the measured number; low and high end bracket the measured number.
By their numbers in this assay, from the lowest: compounds 1 and 3 (each within the scatter of the next); then compound 2.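

In this assay, placing 1-methyl-1H-imidazol-2-yl on this aromatic carbon in place of 1-methyl-1H-pyrrol-2-yl gives a 3.2-fold lower number from compound 2 to compound 3 (0.50 log units; beyond the scatter), so the number set by the ring with one hetero atom is not fixed at this position. The comparison with 1-methyl-1H-pyrazol-3-yl, a 2.0-fold higher number from compound 1 to compound 3 (0.30 log units; within the scatter), does not separate the two rings with two hetero atoms. No measurement at hand accounts for these results.

The compounds shown leave open how a plain phenyl ring or a triazole ring would fare here. They also leave open whether the ring's methyl group matters, as an imidazole without it would test.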